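This account rests on a few compounds, and the source may have more. Where it says the series, first, only, none or still open, it means among the compounds named here.

Of the compounds shown here, three sharing one core have been measured. Compound 1 `O=C(CN1CCCC1)N1CCC(NS(=O)(=O)c2cc(S(=O)(=O)c3ccccc3)ccc2C(F)(F)F)CC1` gives 190 nM in a functional assay on U2OS cells for antagonist activity at proto-oncogene Wnt-3 (Homo sapiens), read by a luciferase reporter, with a stated time of 18 h; on this read-out lower numbers stand for an effect already at smaller amounts and higher numbers for an effect only at larger amounts of compound. Compound 2 `O=C(Cn1ccnc1)N1CCC(NS(=O)(=O)c2cc(S(=O)(=O)c3ccccc3)ccc2C(F)(F)F)CC1` gives 230 nM in this assay, and compound 3 `CC(C)(C)OC(=O)N1C(=O)CC[C@H]1C(=O)N1CCC(NS(=O)(=O)c2cc(S(=O)(=O)c3ccccc3)ccc2C(F)(F)F)CC1` gives 90 nM. Compound 2 holds the highest of the three numbers: its nearest neighbour is compound 1, separated by a 1.2-fold higher number from compound 1 to compound 2 (0.08 log units; within the scatter), and its furthest is compound 3, whose lower number lies beyond the scatter. Compound 4 `CC(C)(C)C(=O)N1CCC[C@H]1C(=O)N1CCC(NS(=O)(=O)c2cc(S(=O)(=O)c3ccccc3)ccc2C(F)(F)F)CC1` differs from compound 2 by 1-((tert-butyl)carbonyl)pyrrolidin-2-yl in place of (1H-imidazol-1-yl)methyl on a carbonyl carbon. Among the compounds with values here, the only measured single-point step, a 1.2-fold higher number from compound 1 to compound 2 (0.08 log units; within the scatter), swaps one small ring-bearing group for another and is within the scatter, so it gives little guidance for a change of this size. Compound 3 carries a substituted pyrrolidinyl ring on the same carbonyl carbon and gives 90 nM, which is the closest measured analogue. Compound 4 is therefore expected to give 100 nM, with a range from 40 nM to 250 nM. This estimate corresponds to an expected step of a 2.3-fold lower number from compound 2 to compound 4 (0.36 log units; beyond the scatter), a lower number beyond the scatter.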

Compound 4, half-maximal effective concentration: 270 nM
For compound 4 the middle estimate is 2.7-fold (0.43 log units) below the measured one; measured number above the stated range.
By their numbers in this assay, from the lowest: compound 3; then compounds 1, 2 and 4 (each within the scatter of the next).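

On the carbonyl carbon, 1-((tert-butyl)carbonyl)pyrrolidin-2-yl in place of (1H-imidazol-1-yl)methyl gives a 1.2-fold higher number from compound 2 to compound 4 (0.07 log units; within the scatter), and in place of (pyrrolidin-1-yl)methyl it gives a 1.4-fold higher number from compound 1 to compound 4 (0.15 log units; within the scatter), so this assay does not separate these three groups, even though the entering group brings a non-aromatic ring and a defined stereocentre. Compound 3 goes against this flat picture at 90 nM, while compound 4 gives 270 nM, so a five-membered non-aromatic ring on this carbon does not by itself go with the lower number. Nothing measured here explains why these groups read alike.

The compounds shown leave open whether the lower number of compound 3 goes with its ring carbonyl or with its tert-butoxycarbonyl group, as compound 3 and compound 4 differ in both. Going by these compounds, how a primary amine or a carboxylic acid on this carbonyl carbon's substituent would read also remains open.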